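One side-chain change at the assay limit

The source may hold more compounds than are shown below. What is called first, only, known or untested is meant among the compounds shown, and "the series" means these compounds.

Measured in a functional assay on MV4-11 cells (Homo sapiens) for antiproliferative activity, read by CellTiter-Glo, with a stated time of 72 h (on this read-out lower numbers stand for stronger inhibition of growth and higher numbers for weaker inhibition of growth), where both values are limits and not numbers:
Compound 1 (`CC(C)(C)OC(=O)Nc1nc(-c2cc(F)ncc2Cl)cs1`): > 10000 nM
Compound 2 (`COCCNc1cc(-c2csc(NCC3CCOCC3)n2)c(Cl)cn1`): > 10000 nM

Compound 2 gives no number, only a limit (> 10000 nM). The two measured compounds therefore sit at the same place (the limit of > 10000 nM in this assay, at which 2 of the 2 values shown sit). Compound 3 (`N[C@H]1CC[C@H](CNc2cc(-c3csc(NCC4CCOCC4)n3)c(Cl)cn2)CC1`) differs from compound 2 in one place (4-aminocyclohexyl in place of methoxymethyl on a saturated chain carbon bound to a nitrogen on an aromatic ring): 4-aminocyclohexyl in place of methoxymethyl on a saturated chain carbon bound to a nitrogen on an aromatic ring. Cut one bond further out, 2-methoxyethyl becomes (4-aminocyclohexyl)methyl. Within the data shown here, no pair of measured compounds shows what a change like this does, so the expectation rests on the structural change alone and stays wide. A large step towards stronger inhibition of growth is expected (an at least 33-fold lower number from compound 2 to compound 3 (1.52 log units; beyond the scatter)). In this assay the expected value for compound 3 is 300 nM (estimated range 30 nM to 3000 nM).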

Compound 3, concentration for 50% growth inhibition: 1900 nM
Beside the measured number, compound 3's estimate is 6.3-fold (0.80 log units) below it; the range from low to high includes it.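

In this assay, the position on a saturated chain carbon bound to a nitrogen on an aromatic ring proves able to move growth inhibition into a measurable range: replacing 2-methoxyethyl with (4-aminocyclohexyl)methyl gives an at least 5.2-fold lower number from compound 2 to compound 3 (0.72 log units; beyond the scatter). From the compounds shown here alone, compound 2 gives > 10000 nM, which is a limit and not a number, so the true size of this step stays unknown. Compound 3 is the only compound shown that gives a number rather than a limit, and the other compounds remain at the ceiling: the limit of > 10000 nM in this assay, at which 2 of the 3 values shown sit.

Going by these compounds, the amine and the cyclohexane ring enter together, so their separate contributions remain open. A cyclohexylmethyl group without the amine, or a 2-aminoethyl chain without the ring, would help to tell them apart.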